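A few compounds are considered here, and "the series" means these few. Any claim that something is new, unique, unknown or untested is made for them only; others in the source may bear on it.

Measured compounds:
compound 1 `CS(=O)(=O)N(CC1CC1)c1ccccc1N1CCN(C(=O)[C@H](CC(=O)N2CCNCC2)Cc2ccc(Cl)cc2)CC1` gives > 8000 nM in an assay on isolated protein for inhibition of Melanocortin receptor 3 (Homo sapiens); on this read-out lower numbers stand for stronger inhibition and higher numbers for weaker inhibition
compound 2 `CC(=O)N1CCN(C(=O)C[C@H](Cc2ccc(Cl)cc2)C(=O)N2CCN(c3ccccc3N(CC3CC3)S(C)(=O)=O)CC2)CC1` gives > 10000 nM in this assay

In this assay compound 1 reaches only a limit, > 8000 nM. In the same assay compound 2 likewise reaches only a limit, > 10000 nM. The step between them, a step that the two limits leave unreadable from compound 1 to compound 2, is therefore not readable, as the limit of > 10000 nM in this assay, at which 1 of the 2 values shown sits, and the limit of > 8000 nM in this assay, at which 1 of the 2 values shown sits, show.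

Compound 3 `CC(C)(C)CC(=O)N1CCN(C(=O)C[C@H](Cc2ccc(Cl)cc2)C(=O)N2CCN(c3ccccc3N(CC3CC3)S(C)(=O)=O)CC2)CC1` follows from compound 2 by tert-butyl in place of hydrogen on a saturated chain carbon bound to a carbonyl carbon. Within the data shown here, no measured step bears on this change directly: the only measured step, a step that the two limits leave unreadable from compound 1 to compound 2, is unreadable, and it concerns a different change at the same amide nitrogen. Both measured compounds sit at a limit, so there is no number from which a step could be expected in either direction beyond the scatter. Compound 2 stands at the weaker limit of the two values shown, and nothing indicates that the neopentylcarbonyl in compound 3 would move it.

Compound 3 is accordingly expected to give 20000 nM in this assay, with a range from 5000 nM to 100000 nM. The expected step that the limit leaves unreadable from compound 2 to compound 3 is essentially none, and the estimate most likely comes back as a limit again.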

Compound 3, half-maximal inhibitory concentration: > 10000 nM
Compound 3: only a limit was reported; the forecaster's own chance of this, stated with the estimate: 85%; the middle value lies beyond the limit too.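

In this assay compound 3 gives > 10000 nM, which is a limit and not a number. With compound 1 and compound 2 also known only as limits, the steps from compound 1 and compound 2 to compound 3 cannot be read. The compounds shown leave open whether hydrogen, acetyl or neopentylcarbonyl on the amine nitrogen in a ring makes any difference to inhibition.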